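This account rests on a few compounds, and the source may have more. Where it says the series, first, only, none or still open, it means among the compounds named here.

Measured so far:
- compound 1, `O=C([C@@H]1CCCN(S(=O)(=O)c2ccc(S(=O)(=O)C3CCC3)cc2)C1)N1CCC(F)(F)CC1`: 12.6 nM
- compound 2, `CCN(CC)S(=O)(=O)c1ccc(S(=O)(=O)N2CCC[C@@H](C(=O)N3CCC(OC)CC3)C2)cc1`: 50 nM

Both were tested in a functional assay on MIA PaCa-2 cells (Homo sapiens) for inhibition, read by MTT assay, with a stated time of 3 days; a higher number here means a weaker inhibitor, a lower number a stronger inhibitor. Of the two numbers, compound 2 gives the higher one with 50 nM, and compound 1 the lower with 12.6 nM; the gap between them is beyond the usual scatter, so compound 1 is the stronger inhibitor of the pair. Among the measured compounds shown here, no single-point step between these two compounds is available, as they differ in more than one place.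

Compound 3, `CCN(CC)S(=O)(=O)c1ccc(S(=O)(=O)N2CCC[C@@H](C(=O)N[C@@H]3CCOC3)C2)cc1`, has not yet been measured. It differs from compound 2 by one change: (oxolan-3-yl)amino in place of 4-methoxypiperidin-1-yl on a carbonyl carbon. The amide nitrogen thus carries a hydrogen in compound 3, where in compound 2 it is part of a ring. For the measured compounds named here, no measured pair in this set shows what such a change does, so the expectation rests on compound 2 alone. The step from compound 2 to compound 3 is expected to be small, a 1.6-fold higher number from compound 2 to compound 3 (0.20 log units; within the scatter), toward a weaker inhibitor, and may well sit within the scatter. Compound 3 is therefore estimated at 80 nM, with a range from 25 nM to 250 nM.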

Compound 3, half-maximal inhibitory concentration: 100 nM
Compound 3: the middle estimate sits 1.3-fold (0.10 log units) below what was measured, within the range that was stated.
By their numbers in this assay, from the lowest: compound 1; then compounds 2 and 3 (each within the scatter of the next).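

In this assay, among the compounds shown here, the step of a 2.0-fold higher number from compound 2 to compound 3 (0.30 log units; within the scatter) gives the first direct reading at this position, the group on the carbonyl carbon. It replaces 4-methoxypiperidin-1-yl with (oxolan-3-yl)amino, which brings a five-membered ring in place of a six-membered one, adds the amide hydrogen and introduces a defined stereocentre, yet the two numbers cannot be told apart in this assay. This position therefore tolerates this combined change without a clear loss or gain, at least for this pair on this core. No accompanying measurement offers an explanation for this result.

The single swap changes ring size, amide hydrogen and stereocentre together, and the compounds shown do not reveal what each of these contributes alone. Also open, on these data alone, is how the same position would respond to a group of a different kind on the carbonyl carbon, such as an open-chain ethylamino group or a morpholin-4-yl ring, and whether a step of that kind would stand clear of the scatter.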